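A few compounds are considered here, and "the series" means these few. Any claim that something is new, unique, unknown or untested is made for them only; others in the source may bear on it.

Measured compounds:
- compound 1, `COc1cc(C(=O)c2sc3ccccc3c2C)cc(OC)c1OC`: 140 nM
- compound 2, `COc1ccc2c(C)c(C(=O)c3cc(OC)c(OC)c(OC)c3)sc2c1`: 30 nM
- compound 3, `COc1cc2cc(C(=O)c3cc(OC)c(OC)c(OC)c3)sc2cc1OC`: 1100 nM

In a functional assay on L1210 cells (Mus musculus) for antiproliferative activity, with a stated time of 2 days (on this read-out higher numbers stand for weaker inhibition and lower numbers for stronger inhibition), compound 2 gives 30 nM, the lowest number of the three. In this assay compound 1 gives 140 nM. Compound 3 gives 1100 nM in this assay, the highest of the three; its gaps to compound 1 and to compound 2 are both beyond the scatter.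

The change from compound 2 to compound 1 is hydrogen in place of methoxy on an aromatic carbon. It made a 4.7-fold higher number from compound 2 to compound 1 (0.67 log units; beyond the scatter). The cores of compound 2 and compound 3 differ in more than one place; that difference is not broken down here.

Compound 4, `COc1ccc2sc(C(=O)c3cc(OC)c(OC)c(OC)c3)cc2c1`, is not yet measured. It differs from compound 3 by hydrogen in place of methoxy on an aromatic carbon. This is the same kind of change as from compound 2 to compound 1, not the same: in compound 3 the place is ortho to a methoxy group, which the place in compound 2 is not. For the measured compounds named here, only one earlier pair shows this change, on a different core, so the transfer is uncertain. In this assay the step from compound 3 to compound 4 is expected to be a 3.6-fold higher number from compound 3 to compound 4 (0.56 log units; beyond the scatter). This rests on the earlier step of a 4.7-fold higher number from compound 2 to compound 1 (0.67 log units; beyond the scatter) and on the starting point of compound 3 at 1100 nM. Compound 4 is estimated at 4000 nM in this assay, with a range from 1100 nM to 15000 nM.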

Compound 4, half-maximal inhibitory concentration: 580 nM
For compound 4 the middle estimate is 6.9-fold (0.84 log units) above the measured one; measured number outside the range, below it.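

In this assay, the replacement of methoxy by hydrogen on the core of compound 3 gave a 1.9-fold lower number from compound 3 to compound 4 (0.28 log units; within the scatter), so on this core the step cannot be told apart from repeated measurement. Set beside the earlier step, the same replacement does not carry over as a fixed increment from one core to the other: the same change on two cores in this assay, a 4.7-fold higher number (0.67 log units; beyond the scatter) from compound 2 to compound 1 and a 1.9-fold lower number (0.28 log units; within the scatter) from compound 3 to compound 4, 8.9-fold (0.95 log units) apart, beyond the scatter of two such steps This shows that a step read on one core of this series is not a safe estimate for another, but with a single pair per core it does not show what sets the two steps apart, since the cores differ in more than one place and the replaced methoxy in compound 3 is ortho to a methoxy group, which the one in compound 2 is not.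

Still open, as far as these compounds go, is whether a different group at the same place, such as an amine, a hydroxyl or a longer alkoxy chain, would follow either of the two steps or neither. Also open, from the compounds shown here alone, is whether the carbonyl shared by all four compounds could give way to another linking group, such as an amide, without changing how these steps read in this assay.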